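A methyl group leaves compound 2

The source may hold more compounds than are shown below. What is called first, only, known or untested is meant among the compounds shown, and "the series" means these compounds.

Compound 1 `Nc1ncnc2c1ncn2[C@H]1C=C[C@@H](COP2(=O)OCc3ccccc3O2)O1` with 0.01 h measured
Compound 2 `Cc1cc(C)c2c(c1)COP(=O)(OC[C@@H]1C=C[C@H](n3cnc4c(N)ncnc43)O1)O2` with 0.01 h measured

In an ADME assay for metabolic stability, at pH 1.5 (on this read-out higher numbers stand for a longer-lived compound and lower numbers for a shorter-lived compound), compound 2 gives 0.01 h as its reading, level with compound 1 within the scatter. The change to compound 3 `Cc1cccc2c1OP(=O)(OC[C@@H]1C=C[C@H](n3cnc4c(N)ncnc43)O1)OC2` is hydrogen in place of methyl on an aromatic carbon and amounts to hydrogen in place of methyl on an aromatic carbon. Among the measured compounds shown here, no measured pair isolates this change. Compound 1 lacks the methyl groups of compound 2, yet compound 1 reads 0.01 h all the same, so no step beyond the scatter is expected in this assay here. The step expected is no change at the digits printed from compound 2 to compound 3 (within the scatter) by this estimate. For compound 3 the estimated value is 0.01 h with an expected range of 0.005 h to 0.02 h in this reading.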

Compound 3, half-life in the ADME assay: 0.0098 h
The estimate for compound 3 lay 1.0-fold (0.01 log units) above the measured number; the measured number falls inside the stated range.
By their numbers in the ADME assay, from the lowest: compounds 3, 1 and 2 (each within the scatter of the next).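

In the ADME assay this change can now be read directly, and neither step separates the compounds: a 1.0-fold lower number from compound 2 to compound 3 (0.01 log units; within the scatter), and a 1.0-fold lower number from compound 1 to compound 3 (0.01 log units; within the scatter). On this half-life read-out, methyl and hydrogen at this aromatic carbon therefore come out level. The same replacement does register in a physicochemical assay for lipophilicity (a higher number here means a more lipophilic compound, a lower number a more polar compound), where compound 2 gives 0.95 and compound 3 gives 0.63, and compound 3 is the more polar of the pair: the measured partition coefficient of compound 2, 0.95, and of compound 3, 0.63, a number 0.32 log units lower (beyond the scatter)

Still open, from the compounds shown here alone, is whether a group other than methyl at this position, such as an amine or a carboxylic acid, would move the half-life in the ADME assay at all.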